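Adding a Hydroxy Group to Compound 2

This account rests on a few compounds, and the source may have more. Where it says the series, first, only, none or still open, it means among the compounds named here.

Of the compounds shown here, two have so far been read in an ADME assay on HEK-293T cells (Homo sapiens) for cytotoxicity, read by CCK-8 assay, with a stated time of 48 h (a lower number here means a stronger inhibitor, a higher number a weaker inhibitor), and only one gives a number. Compound 1 (`O=S(=O)(NCCNC(=S)Nc1cccc(Cl)c1)c1ccc(-c2ccccc2OCc2cccc(O)c2)s1`) gives 17400 nM as a measured value. Compound 2 (`Cc1cc(C)cc(NC(=O)NCCNS(=O)(=O)c2ccc(-c3ccccc3OCc3ccccc3)s2)c1`) gives > 20000 nM in this assay and this is a limit of the assay, not a number.

Compound 3 (`Cc1cc(C)cc(NC(=O)NCCNS(=O)(=O)c2ccc(-c3ccccc3OCc3cccc(O)c3)s2)c1`) differs from compound 2 in one place: hydroxy in place of hydrogen on an aromatic carbon with hydroxy in place of hydrogen on an aromatic carbon, turning benzyloxy into (3-hydroxybenzyl)oxy. Going by the values given here, no measured pair isolates this change. Compound 1 carries the same (3-hydroxybenzyl)oxy group but differs from compound 3 elsewhere as well. Among the compounds with values here, with compound 1 at 17400 nM as the only reading for a compound bearing this group, no shift beyond the scatter is expected in this assay and any movement should be towards a lower number. The step of an at least 1.1-fold lower number from compound 2 to compound 3 (0.04 log units; that floor lies within the scatter) is therefore expected to be small. For compound 3 the expected value is 18000 nM with an estimated range from 9000 nM to 30000 nM and a real chance that the assay reports only a limit.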

Compound 3, half-maximal inhibitory concentration: > 20000 nM
Compound 3 gave a limit, no number; the forecaster's own chance of this, stated with the estimate: 45%; at least 1.1-fold (0.04 log units) between middle value and limit.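

In this assay compound 3 gives > 20000 nM, which is a limit of the assay and not a number. Adding the hydroxy group to the benzyloxy group of compound 2 therefore produces no readable value, and the step between the two cannot be read, because both compounds end at the same limit: the limit of > 20000 nM in this assay, at which 2 of the 3 values shown sit. With the (3-hydroxybenzyl)oxy group held constant, replacing the group on the amine nitrogen gives an at least 1.1-fold higher number from compound 1 to compound 3 (0.06 log units; that floor lies within the scatter), so the compounds shown do not establish a real difference between this pair.

From the compounds shown here alone, whether hydroxy in place of hydrogen at this position changes the cytotoxicity reading at all remains open, since any shift would have to be seen in compounds that read clear of the limit. Going by these compounds, how a methoxy group, an amine or a carboxylic acid would read at the same place on the ring also remains open.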